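The compounds below may be only part of what the source reports. "The series", "measured", "known", "first", "only" and "open" are said of these compounds alone.

Working notes on the series, read in a functional assay on HFF cells (Homo sapiens) for cytotoxicity; on this read-out lower numbers stand for stronger inhibition and higher numbers for weaker inhibition. Compound 1 `CCCCOC[C@H]1OC(n2c(Cl)nc3cc(Cl)c(Cl)cc32)[C@H](O)[C@@H]1O` gives 32000 nM, compound 2 `O[C@@H]1[C@@H](CF)OC(n2c(Cl)nc3cc(Cl)c(Cl)cc32)[C@@H]1O` gives 32000 nM and compound 3 `O[C@@H]1[C@@H](CI)OC(n2c(Cl)nc3cc(Cl)c(Cl)cc32)[C@@H]1O` gives 32000 nM, so compound 3 stands level with compound 1 and compound 2 at the digits available.

The step under consideration leads to compound 4 `[N-]=[N+]=NC[C@H]1OC(n2c(Cl)nc3cc(Cl)c(Cl)cc32)[C@H](O)[C@@H]1O` with this difference: azido in place of iodo on a saturated chain carbon bound to a saturated ring carbon. In words, this is azido in place of iodo on a saturated chain carbon bound to a saturated ring carbon. Among the compounds with values here, three measured steps bear on it, all at that same place: no change at the digits printed from compound 1 to compound 2 (within the scatter), no change at the digits printed from compound 1 to compound 3 (within the scatter) and no change at the digits printed from compound 2 to compound 3 (within the scatter). Butoxy, fluoro and iodo thus read alike, but azido has no measurement at this place yet. On these three steps, no shift beyond the scatter is expected in this assay, and no direction can be assigned.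

The expected step is no change at the digits printed from compound 3 to compound 4 (within the scatter).

For compound 4 the estimated value is 32000 nM with an expected range of 16000 nM to 64000 nM.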

Compound 4, half-maximal inhibitory concentration: 32000 nM
Compound 4: the middle estimate sits on the measured number at the digits printed; the measured number falls inside the stated range.
By their numbers in this assay, from the lowest: compounds 1, 2, 3 and 4 (each within the scatter of the next).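

In this assay the new steps run no change at the digits printed from compound 3 to compound 4 (within the scatter) and no change at the digits printed from compound 2 to compound 4 (within the scatter) and also no change at the digits printed from compound 1 to compound 4 (within the scatter) on the saturated chain carbon bound to a saturated ring carbon. Azido, with its 3 heavy atoms and 2 double bonds outside aromatic rings, thus joins butoxy, fluoro and iodo as a fourth group at this place that reads alike, and the earlier compounds did not cover this kind of group. No measurement at hand explains this flat reading.

Going by these compounds, whether an amine, a carboxylic acid or a chain longer than butoxy at this place would read the same remains open. All four compounds share one level, so they do not show what, if anything, would move this read-out from this place.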